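The compounds below may be only part of what the source reports. "The series", "measured", "known", "first", "only" and "open" are said of these compounds alone.

Working notes on the series. In an ADME assay on HOS cells (Homo sapiens) for cytotoxicity (on this read-out lower numbers stand for stronger inhibition and higher numbers for weaker inhibition), compound 1 (`O=C1c2c(ccc(O)c2O)CN1Cc1cccc(F)c1`) gives 8600 nM as its read-out, and compound 2 (`O=C1c2c(ccc(O)c2O)CN1Cc1cccc(Cl)c1`) gives 9020 nM on the same read-out. Compound 2 therefore stands level with compound 1, and the two cannot be told apart within the scatter. The next analogue is compound 3 (`O=C1c2c(ccc(O)c2O)CN1Cc1cccc(Br)c1`), still unmeasured. Its difference from compound 2 is bromo in place of chloro on an aromatic carbon in the counted terms, that is, bromo in place of chloro on an aromatic carbon, meta to a large group. Among the measured compounds shown here, one measured step bears on this change: chloro in place of fluoro at the same place on the shared core, which came out as a 1.0-fold higher number from compound 1 to compound 2 (0.02 log units; within the scatter) for that exchange. Because of a 1.0-fold higher number from compound 1 to compound 2 (0.02 log units; within the scatter) no step beyond the scatter is expected for the further exchange to bromo in this assay on this evidence. One step is thin support, so the range is kept wide. The expected change is a 1.0-fold lower number from compound 2 to compound 3 (0.00 log units; within the scatter) on this estimate. For compound 3 the estimated value is 9000 nM with an expected range from 5000 nM to 16000 nM in this read-out.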

Compound 3, half-maximal inhibitory concentration: 7240 nM
Compound 3: middle estimate off by 1.2-fold (0.09 log units), on the high side; low and high end bracket the measured number.
By their numbers in this assay, from the lowest: compounds 3, 1 and 2 (each within the scatter of the next).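

With bromo, the exchange on this aromatic carbon, meta to a large group, now covers three halogens, and in this assay both new steps stay within the scatter: a 1.2-fold lower number from compound 2 to compound 3 (0.10 log units; within the scatter) for bromo in place of chloro, and a 1.2-fold lower number from compound 1 to compound 3 (0.07 log units; within the scatter) for bromo in place of fluoro. Among the compounds shown here, the single earlier step could speak only for fluoro and chloro, whereas compound 1, compound 2 and compound 3 together show that this read-out does not separate any of the three halogens at this place, so no order or trend among them can be read. Nothing at hand offers an explanation for this flat result.

The compounds shown carry only halogens at this place, so it remains open whether a non-halogen group such as an amine, a carboxylic acid or a longer chain would shift the number beyond the scatter. Also open, as far as these compounds go, is whether the same flatness would hold with a halogen elsewhere on this aromatic ring, or with changes to the shared core itself.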